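The compounds below may be only part of what the source reports. "The series", "measured", "known", "first", "only" and "open" are said of these compounds alone.

Measured in a functional assay on HSC-3 cells (Homo sapiens) for cytotoxicity, with a stated time of 48 h; on this read-out lower numbers stand for higher toxicity in this test and higher numbers for lower toxicity in this test:
compound 1 `COc1ccc(/C=C/C(=O)c2c(C)[n+]([O-])c3ccccc3[n+]2[O-])cc1`: 23000 nM
compound 2 `COc1ccc(/C=C/C(=O)c2c(C)[n+]([O-])c3ccccc3[n+]2[O-])cc1OC`: 31000 nM

Compound 1 sits at the low end of the two numbers shown, but the step of a 1.3-fold higher number from compound 1 to compound 2 (0.13 log units; within the scatter) is within the scatter, so the two compounds are not distinguished. Compound 3 `Cc1c(C(=O)/C=C/c2ccc(Cl)cc2)[n+]([O-])c2ccccc2[n+]1[O-]` differs from compound 1 by chloro in place of methoxy on an aromatic carbon. For the measured compounds named here, no measured step exchanges one substituent for another at that position; the only step on record, a second methoxy entering, is within the scatter. With nothing bearing on the exchange, the step of a 1.1-fold higher number from compound 1 to compound 3 (0.04 log units; within the scatter) is expected to be none beyond the scatter. Compound 3 is estimated at 25000 nM, with a range from 8000 nM to 70000 nM.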

Compound 3, half-maximal cytotoxic concentration: 38000 nM
Estimate against measurement, compound 3: 1.5-fold (0.18 log units) below, and the stated range covers the measured number.
By their numbers in this assay, from the lowest: compounds 1, 2 and 3 (each within the scatter of the next).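

The 4-methoxyphenyl to 4-chlorophenyl exchange replaces the methoxy instead of adding a second one, and in this assay the step of a 1.7-fold higher number from compound 1 to compound 3 (0.22 log units; within the scatter) stays within the scatter. At this place, para to a large group, chloro and methoxy are therefore not distinguished. No evidence available here bears on this result.

From the compounds shown here alone, whether an amine or a carboxylic acid at this place would move the number beyond the scatter remains open. Going by these compounds, the shared core is constant across all three compounds, so its contribution also remains open.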